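Exchange of the phenyl group across two cores

The source may report more compounds than this note shows. Statements on the series, on what has been measured and on what is new or still open speak of the compounds shown alone.

Compound 1 `O=C(CN1CCN(c2cccc(C(F)(F)F)c2)CC1)NNc1nncc2ccccc12` and compound 2 `COc1ccccc1N1CCN(CC(=O)NNc2nncc3ccccc23)CC1` share one core and differ only in the group on the ring nitrogen. In a functional assay on thoracic aorta (Rattus norvegicus, strain Wister) (on this read-out higher numbers stand for weaker inhibition and lower numbers for stronger inhibition), compound 1 gives 410000 nM, and compound 2 gives 550000 nM. The change between them, (2-methoxyphenyl in place of 3-(trifluoromethyl)phenyl on an amine nitrogen in a ring), produced a 1.3-fold higher number from compound 1 to compound 2 (0.13 log units; within the scatter).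

Compound 3 `O=C(CCN1CCN(c2cccc(C(F)(F)F)c2)CC1)NNc1nncc2ccccc12` carries a different core; the difference between the core of compound 3 and the core of compound 1 is not broken down here. In this assay compound 3 gives 500000 nM, which sits within the scatter of both compound 1 and compound 2.

Compound 4 `COc1ccccc1N1CCN(CCC(=O)NNc2nncc3ccccc23)CC1` is not yet measured. It is related to compound 3 by 2-methoxyphenyl in place of 3-(trifluoromethyl)phenyl on an amine nitrogen in a ring. This is the same change as the one between compound 1 and compound 2, on a position described in identical words, and it occurs in two pairs among the compounds shown. Among the measured compounds shown here, the one measured instance of this change, a 1.3-fold higher number from compound 1 to compound 2 (0.13 log units; within the scatter), stayed within the scatter, and the two cores give values within the scatter of each other. The step in this assay from compound 3 to compound 4 is therefore expected to be small, a 1.3-fold higher number from compound 3 to compound 4 (0.11 log units; within the scatter), resting on a 1.3-fold higher number from compound 1 to compound 2 (0.13 log units; within the scatter). Compound 4 is estimated at 650000 nM in this assay, with an expected range from 300000 nM to 1400000 nM. Given how weak all three measured compounds are, a limit rather than a number remains possible for compound 4.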

Compound 4, half-maximal inhibitory concentration: 100000 nM
Compound 4: middle estimate off by 6.5-fold (0.81 log units), on the high side; measured number below the stated range.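

In this assay, the exchange of 3-(trifluoromethyl)phenyl for 2-methoxyphenyl on the ring nitrogen gives a 5.0-fold lower number from compound 3 to compound 4 (0.70 log units; beyond the scatter), so here the change moves the read-out towards stronger inhibition beyond the scatter. Its effect therefore does not carry over unchanged from one core to the other: the same change on two cores in this assay, a 1.3-fold higher number (0.13 log units; within the scatter) from compound 1 to compound 2 and a 5.0-fold lower number (0.70 log units; beyond the scatter) from compound 3 to compound 4, 6.7-fold (0.83 log units) apart, beyond the scatter of two such steps

Among the compounds shown here, the result shows that, for these two pairs, the step measured on the core of compound 1 was a poor guide to the step on the core of compound 3, but it does not show why the two differ, and with only one pair on each core it sets no general rule for the series.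

Still open, going by these compounds, is whether the same dependence on the core appears with other groups on the ring nitrogen, such as unsubstituted phenyl or 2-chlorophenyl, or whether it is particular to the two groups compared here. Also open, on these data alone, is how the exchange behaves on a core with a longer chain, which would show whether the step seen on the core of compound 3 persists or fades.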